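The source may report more compounds than this note shows. Statements on the series, on what has been measured and on what is new or still open speak of the compounds shown alone.

Measured compounds:
compound 1, `Cn1cc(SCc2nnc(SCc3ccccc3)n2-c2c(Cl)cccc2Cl)c2ccccc21`
compound 2, `Cn1cc(SCc2nnc(SCc3cc(Cl)ccc3Cl)n2-c2c(Cl)cccc2Cl)c2ccccc21`

In a toxicity assay on HEK-293T cells (Homo sapiens) for cytotoxicity, read by CCK-8 assay, with a stated time of 48 h (a higher number here means that more compound is tolerated, a lower number that less compound is tolerated), compound 1 gives > 100000 nM, which is a limit of the assay and not a number. In this assay compound 2 likewise gives > 100000 nM, again a limit. The step that the two limits leave unreadable from compound 1 to compound 2 is therefore not readable. Compound 2 thus stands only at a limit on the numbers shown, with nothing else to place it: the limit of > 100000 nM in this assay, at which 2 of the 2 values shown sit.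

Compound 3, `Cn1cc(SCc2nnc(SCc3ccc(Cl)cc3F)n2-c2c(Cl)cccc2Cl)c2ccccc21`, differs from compound 2 in one place: 4-chloro-2-fluorophenyl in place of 2,5-dichlorophenyl on a saturated chain carbon bound to a sulfur. Within the data shown here, the only measured step touching this position is a step that the two limits leave unreadable from compound 1 to compound 2, which the two limits leave unreadable, so no sized step bears on the change. For compound 3 in this assay no movement beyond the scatter is expected, the step that the limit leaves unreadable from compound 2 to compound 3 being a nominal one. Compound 3 is estimated at 150000 nM in this assay, with a range from 60000 nM to 400000 nM, most likely again reported only as a limit.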

Compound 3, half-maximal cytotoxic concentration: 87300 nM
Estimate against measurement, compound 3: 1.7-fold (0.24 log units) above; the range from low to high includes it.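

In this assay, among these compounds, compound 3 gives 87300 nM, the first reading at this position on a saturated chain carbon bound to a sulfur that is a number and not a limit. Compound 1 and compound 2 both sit at a limit, so the step between them cannot be read: the limit of > 100000 nM in this assay, at which 2 of the 3 values shown sit.

Placing 4-chloro-2-fluorophenyl at this position gives an at least 1.1-fold lower number from compound 2 to compound 3 (0.05 log units; that floor lies within the scatter) and an at least 1.1-fold lower number from compound 1 to compound 3 (0.05 log units; that floor lies within the scatter); both are floors, so they fix no exact size and show no shift beyond the scatter.

The compounds shown leave open how the number responds at this position to a group other than a plain or chlorinated phenyl, such as an amine, a carboxylic acid or a longer chain before the ring. They also leave open whether a change on the shared core would move it.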